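Sec-butyl for pyrrolidin-1-yl on the shared core

The compounds below may be only part of what the source reports. "The series", "measured", "known", "first", "only" and "open" are said of these compounds alone.

In an ADME assay on microsomes from liver (Rattus norvegicus, strain Sprague-Dawley) for metabolic stability, read by LC-MS, with a stated time of 15 min, tested at 20 uM (a lower number here means that less of the compound is left, a higher number that more of the compound is left), compound 3 (`O=C(Oc1ccccc1N1CCCC1)c1coc(-c2ccccc2)n1`) stands at 11.2% and lies within the scatter of compound 1 (`CCC(=O)c1ccccc1OC(=O)c1coc(-c2ccccc2)n1`) at 8.7% while compound 2 (`Cc1cc(C)c(OC(=O)c2coc(-c3ccccc3)n2)c(C)c1`) at 22% lies beyond the scatter above it. Compound 4 (`CCC(C)c1ccccc1OC(=O)c1coc(-c2ccccc2)n1`) carries sec-butyl in place of pyrrolidin-1-yl on an aromatic carbon, ortho to a large group (sec-butyl in place of pyrrolidin-1-yl on an aromatic carbon). Among the compounds with values here, only one measured step bears on this change: pyrrolidin-1-yl in place of propanoyl on an aromatic carbon gave a number 2.5 percentage points higher from compound 1 to compound 3 (within the scatter) and so stayed small. One step is thin evidence, but what is expected here is a number 1.8 percentage points higher from compound 3 to compound 4 (within the scatter) and no shift beyond the scatter. Compound 4 is expected at 13% within an estimated range from 5% to 25% on this read-out.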

Compound 4, percent of the compound remaining: 8.3%
For compound 4 the middle estimate is 4.7 percentage points above the measured one, within the range that was stated.
By their numbers in this assay, from the lowest: compounds 4, 1 and 3 (each within the scatter of the next); then compound 2.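

With sec-butyl as a third group on this aromatic carbon of the shared core, this assay shows a number 2.9 percentage points lower from compound 3 to compound 4 (within the scatter) and a number 0.4 percentage points lower from compound 1 to compound 4 (within the scatter). A group with no ring and no hydrogen-bond acceptor therefore reads within the scatter of both propanoyl and pyrrolidin-1-yl, so none of these three groups separates from the others at this place. No measurement shown gives a reason for this. On these data alone, whether a carboxylic acid or a primary amine here would move the number beyond the scatter remains open.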